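The source may hold more compounds than are shown below. What is called first, only, known or untested is meant among the compounds shown, and "the series" means these compounds.

Measured compounds in the series:
compound 1, `O=C(/C=C/c1ccccc1)Nc1ccc2c(c1)OCCO2`
compound 2, `CCCCc1ccc(/C=C/C(=O)Nc2ccc3c(c2)OCCO3)cc1`
compound 3, `O=C(/C=C/c1ccc(F)cc1)Nc1ccc2c(c1)OCCO2`

In a functional assay on CHO cells for inhibition of transient receptor potential cation channel subfamily V member 1 (Homo sapiens) (on this read-out higher numbers stand for weaker inhibition and lower numbers for stronger inhibition), compound 1 gives > 4000 nM, which is a limit of the assay and not a number. Compound 2 gives 2700 nM. Compound 3 gives > 4000 nM, again a limit of the assay. Compound 3 therefore stands at the limit of > 4000 nM in this assay, at which 2 of the 3 values shown sit, so its standing relative to compound 1 is not readable.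

The next compound is compound 4, `O=C(/C=C/c1ccc(O)cc1)Nc1ccc2c(c1)OCCO2`. The change from compound 3 is hydroxy in place of fluoro on an aromatic carbon. The measured steps that touch the same aromatic carbon are a step that the two limits leave unreadable from compound 1 to compound 3, an at least 1.4-fold lower number from compound 1 to compound 2 (0.17 log units; that floor lies within the scatter) and an at least 1.4-fold higher number from compound 2 to compound 3 (0.17 log units; that floor lies within the scatter); none of them concerns a hydroxy group, and none is readable beyond the scatter. Nothing in the measured steps points to a step beyond the scatter in this assay, in either direction, for compound 4. Compound 4 is estimated at 5000 nM, with a range of 2500 nM to 10000 nM, which means an expected step that the limit leaves unreadable from compound 3 to compound 4; a limit rather than a number is the more likely outcome.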

Compound 4, half-maximal inhibitory concentration: > 4000 nM
Compound 4: no number, only a limit; the forecaster's own chance of this, stated with the estimate: 70%; the middle value does not contradict the limit.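

In this assay compound 4 gives > 4000 nM, which is a limit of the assay and not a number, and it adds a third compound to those at that limit: the limit of > 4000 nM in this assay, at which 3 of the 4 values shown sit. Going by these compounds alone, the only readable step is an at least 1.4-fold higher number from compound 2 to compound 4 (0.17 log units; that floor lies within the scatter), so even against butyl, the hydroxy compound cannot be separated beyond the scatter. The steps to compound 4 from compound 1 and from compound 3 cannot be read, so on this aromatic carbon, hydroxy, with its hydrogen-bond donor, cannot be told apart from hydrogen or fluoro.

As far as these compounds go, it remains open whether ethyl, hexyl or another alkyl chain on this carbon would give a number, and how such a number would compare with that of compound 2. From the compounds shown here alone, an amine or a carboxylic acid at the same place is equally open.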